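Aryl swap on the ring amine: compound 3 to compound 4

The compounds below may be only part of what the source reports. "The series", "measured", "known", "first", "only" and "open" are said of these compounds alone.

Measured compounds:
Compound 1, `CCCc1nc(-c2ccccc2)c(CNCCCN2CCN(c3cccc(C)c3)CC2)o1`: 47.8%
Compound 2, `CCCc1nc(-c2ccccc2)c(CNCCCN2CCN(c3ccccc3C(F)(F)F)CC2)o1`: 45%
Compound 3, `CCCc1nc(-c2ccccc2)c(CNCCCN2CCN(c3ccc(Cl)cc3)CC2)o1`: 63.3%

In an assay on HEK293 cells for inhibition of Voltage-dependent T-type calcium channel subunit alpha-1G (Homo sapiens), read by fluorescence, tested at 10 uM (on this read-out lower numbers stand for less inhibition and higher numbers for more inhibition at the one concentration tested (going by the name of the read-out)), compound 3 stands highest of the three numbers: its nearest neighbour is compound 1, and compound 2 lies furthest away. Compound 4, `CCCc1nc(-c2ccccc2)c(CNCCCN2CCN(c3ccccc3C)CC2)o1`, is the compound not yet measured. It differs from compound 3 in one place, (2-methylphenyl in place of 4-chlorophenyl on an amine nitrogen in a ring).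

Going by the values given here, two measured steps bear on this change, both swaps of the aryl group on the same ring nitrogen. The step of a number 15.5 percentage points higher from compound 1 to compound 3 (beyond the scatter) and the step of a number 18.3 percentage points higher from compound 2 to compound 3 (beyond the scatter) both lead up to the 4-chlorophenyl compound from a methylphenyl or a trifluoromethylphenyl. Going the other way, away from 4-chlorophenyl to 2-methylphenyl, the author therefore expects a modest loss in this assay, of a size comparable to those two steps. Compound 4 is expected to give about 47%, within a range of 35% to 60%, which would mean an expected step of a number 16.3 percentage points lower from compound 3 to compound 4 (beyond the scatter).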

Compound 4, a percentage reported as inhibition, at one concentration (the size of the read-out at that concentration, not a potency): 54.5%
Beside the measured number, compound 4's estimate is 7.5 percentage points below it; measured number inside the range.
By their numbers in this assay, from the lowest: compounds 2, 1, 4 and 3 (each within the scatter of the next, the first and the last beyond it).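

On this ring nitrogen in this assay, the change to 2-methylphenyl gives a number 8.8 percentage points lower from compound 3 to compound 4 (within the scatter), so the 4-chlorophenyl group cannot be told apart from this aryl group, although it stood clear of the two aryl groups tried earlier. The 2-methylphenyl group also cannot be told apart from those two: the change from 3-methylphenyl gives a number 6.7 percentage points higher from compound 1 to compound 4 (within the scatter), and methyl in place of trifluoromethyl on an aromatic carbon gives a number 9.5 percentage points higher from compound 2 to compound 4 (within the scatter). No measurement here offers an explanation for these numbers.

The compounds leave open whether the chlorine itself or its place on the aromatic ring matters more, a question that 2-chlorophenyl and 4-methylphenyl groups on the same nitrogen could address. An unsubstituted phenyl group there would also give a reference for all of these substituents.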